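Lengthening the Thioamide Chain on Compound 1

The source may report more compounds than this note shows. Statements on the series, on what has been measured and on what is new or still open speak of the compounds shown alone.

Measured so far:
compound 1, `N=C(S)CCCn1nc(-c2ccccc2)ccc1=O`: 31.9 mg/kg
compound 2, `N=C(S)CCCCCCN1N=C(c2ccccc2)CCC1=O`: 58.8 mg/kg

On a functional assay on the whole organism (stomach) with Rattus norvegicus as the target (on this read-out lower numbers stand for an effect already at smaller amounts and higher numbers for an effect only at larger amounts of compound), compound 1 stands lowest of the two numbers, but compound 2 lies close to it and that gap is within the usual scatter of repeated measurements, so no order between the two can be read from these values. Compound 3, `N=C(S)CCCCCCn1nc(-c2ccccc2)ccc1=O`, has not yet been measured. It differs from compound 1 in that (a group of 6 heavy atoms (4 carbon, 1 nitrogen, 1 sulfur; no ring) in place of a group of 3 heavy atoms (1 carbon, 1 nitrogen, 1 sulfur; no ring), on a saturated chain carbon, three bonds along the chain from an aromatic nitrogen). Going by the values given here, no pair of measured compounds differs in exactly this one place, so the size of such a step is not known from the data. The two numbers in hand lie close together despite the differences between those compounds, which gives no hint of a large move in either direction. The step from compound 1 to compound 3 is therefore expected to be a 1.4-fold higher number from compound 1 to compound 3 (0.15 log units; within the scatter), that is, nothing beyond the scatter. Compound 3 is estimated at 45 mg/kg with a range from 20 mg/kg to 100 mg/kg.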

Compound 3, dose for half-maximal effect: > 100 mg/kg
Compound 3 ended at the assay's limit (the forecaster's own chance of this, stated with the estimate: 5%); middle value at least 2.2-fold (0.34 log units) away from the limit.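

In this assay compound 3 gives > 100 mg/kg, which is a limit of the assay and not a number: the limit of > 100 mg/kg in this assay, at which 1 of the 3 values shown sits. At this position, on a saturated chain carbon, three bonds along the chain from an aromatic nitrogen, the group of 6 heavy atoms in place of the group of 3 heavy atoms gives an at least 3.1-fold higher number from compound 1 to compound 3 (0.49 log units; beyond the scatter). Going by these compounds alone, this is the first step read at this place, and it shows that the change moves the read-out beyond the scatter, which compounds 1 and 2, differing in more than one place, could not show.

Going by these compounds, how the read-out runs for a chain of intermediate length remains open. So does the effect of an amine or a carboxylic acid in place of these groups on the core of compound 1.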